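This account rests on a few compounds, and the source may have more. Where it says the series, first, only, none or still open, it means among the compounds named here.

Measured in a toxicity assay on HeLa cells (Homo sapiens) for cytotoxicity; a lower number here means that less compound is tolerated, a higher number that more compound is tolerated:
- Compound 1 `CC(C)CCCC(C)CCOc1ccc(C2SCC(=O)N2Cc2ccccc2)cc1`: 66000 nM
- Compound 2 `CC(C)=CCC/C(C)=C/COc1ccc(C2SCC(=O)N2Cc2ccccc2)cc1`: > 100000 nM
- Compound 3 `CC1(C)C2CC=C(CCOc3ccc(C4SCC(=O)N4Cc4ccccc4)cc3)C1C2`: > 100000 nM

Only compound 1 has an actual number. In this assay compound 3 is reported as > 100000 nM, which is a limit and not a number. Compound 2 is also reported only as a limit, and the two share one value: the limit of > 100000 nM in this assay, at which 2 of the 3 values shown sit.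

Compound 4 `CC1=CC[C@@H](CCOc2ccc(C3SCC(=O)N3Cc3ccccc3)cc2)C1(C)C` keeps the shared core of compound 3 and changes one group: a group of 8 heavy atoms (8 carbon; one five-membered non-aromatic ring of carbon only) in place of a group of 9 heavy atoms (9 carbon; one four-membered non-aromatic ring of carbon only, one six-membered non-aromatic ring of carbon only), on a saturated chain carbon, two bonds along the chain from an oxygen on an aromatic ring. The change sits on a saturated chain carbon, two bonds along the chain from an oxygen on an aromatic ring. The entering group has 1 defined stereocentre.

Two measured steps change this same end of the molecule: an at least 1.5-fold higher number from compound 1 to compound 3 (0.18 log units; that floor lies within the scatter), and an at least 1.5-fold higher number from compound 1 to compound 2 (0.18 log units; that floor lies within the scatter). Neither floor goes beyond the scatter. The third step, a step that the two limits leave unreadable from compound 2 to compound 3, cannot be read at all. Going by the values given here, no measured step therefore points to a real shift when the group changes, and compound 1 at 66000 nM is the nearest actual number.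

The expected step is small, no larger than the scatter: an at least 1.1-fold lower number from compound 3 to compound 4 (0.04 log units; that floor lies within the scatter). A limit result is also expected to be quite likely. For compound 4 the estimated value is 90000 nM, with an expected range from 50000 nM to 150000 nM.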

Compound 4, half-maximal cytotoxic concentration: 79000 nM
Compound 4: the middle estimate sits 1.1-fold (0.06 log units) above what was measured, within the range that was stated.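

In this assay compound 4 gives a second actual number at this place on the chain, so a ring-bearing group can now be compared directly with the open chain of compound 1 (a 1.2-fold higher number from compound 1 to compound 4 (0.08 log units; within the scatter)). The five-membered carbon ring group also leaves the result within the scatter when set against the other two groups (an at least 1.2-fold lower number from compound 3 to compound 4 (0.10 log units; that floor lies within the scatter)) and (an at least 1.2-fold lower number from compound 2 to compound 4 (0.10 log units; that floor lies within the scatter)), so none of these changes shows a real shift, although the last two steps are only floors. As far as these compounds go, how far the number could rise at this position remains unknown, since compound 2 and compound 3 are reported only as limits: (the limit of > 100000 nM in this assay, at which 2 of the 4 values shown sit).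

All the groups shown here are built from carbon alone, so it remains open whether an amine, a carboxylic acid or a much shorter chain at this place would move the number beyond the scatter. From the compounds shown here alone, it is also open what the opposite arrangement at the defined stereocentre of compound 4 would give.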